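Furan-to-thiophene swap in two related ester series

The compounds below may be only part of what the source reports. "The series", "measured", "known", "first", "only" and "open" are said of these compounds alone.

Compound 1 `CCCOC(=O)C1=C(C)NC(=O)NC1c1ccoc1` gives 50% in an assay on membranes from CHO cells for displacement of a labelled ligand from adenosine receptor A1 (Homo sapiens), read by scintillation counting, with a stated time of 60 min, tested at 1 uM; on this read-out higher numbers stand for more inhibition at the one concentration tested (going by the name of the read-out) and lower numbers for less inhibition. Compound 2 `CCCOC(=O)C1=C(C)NC(=O)NC1c1cccs1` gives 43% in this assay; the step of a number 7 percentage points lower from compound 1 to compound 2 (within the scatter) arises from thiophen-2-yl in place of furan-3-yl on a saturated ring carbon. Compound 3 `COC(=O)C1=C(C)NC(=S)NC1c1ccoc1` gives 25% in this assay and stands lowest of the three measured numbers. The difference between the core of compound 3 and that of compound 1 is not broken down here. Compound 4 `COC(=O)C1=C(C)NC(=S)NC1c1cccs1` is not yet measured in this assay; it differs from compound 3 by thiophen-2-yl in place of furan-3-yl on a saturated ring carbon. This is the same kind of change as that between the first two compounds, though around the place the ring atom bears a methoxycarbonyl group rather than a propoxycarbonyl group. Within the data shown here, for compound 4 the expected step is a number 5 percentage points lower from compound 3 to compound 4 (within the scatter), resting on the single earlier step of a number 7 percentage points lower from compound 1 to compound 2 (within the scatter) that stayed within the scatter. Compound 4 is estimated at 20%, between 6% and 34%.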

Compound 4, a percentage reported as inhibition, at one concentration (the size of the read-out at that concentration, not a potency): 1%
Estimate against measurement, compound 4: 19 percentage points above; the whole stated range lies above it.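

In this assay, thiophen-2-yl in place of furan-3-yl on a saturated ring carbon does not carry over from one core to the other at a constant size: the same change on two cores in this assay, a number 7 percentage points lower (within the scatter) from compound 1 to compound 2 and a number 24 percentage points lower (beyond the scatter) from compound 3 to compound 4, 17 percentage points apart, beyond the scatter of two such steps. The larger step, a number 24 percentage points lower from compound 3 to compound 4 (beyond the scatter), is seen on the core bearing the methoxycarbonyl group, so the step from the first pair does not serve as a reliable guide on this core. Among these compounds, only two pairs are available, and the cores differ in more than one place, so they do not show which difference between the cores sets the gap.

Open, going by these compounds, is how the same change behaves on a core bearing an ethoxycarbonyl group. Also open, on these data alone, is what a phenyl group would give in place of either five-membered ring.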